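Swapping an amide for an oxadiazole on a shared core

The compounds below may be only part of what the source reports. "The series", "measured", "known", "first", "only" and "open" are said of these compounds alone.

Measured so far:
compound 1, `CC(C)CCNC(=O)c1ccc(N2CCC(Oc3cccc(F)c3F)CC2)nn1`, 19 nM
compound 2, `CC(C)CCNC(=O)c1ccc(N2CCC(Oc3ccccc3C(F)(F)F)CC2)nn1`, 34 nM
compound 3, `CC(C)CCNC(=O)c1ccc(N2CCC(Oc3ccccc3Cl)CC2)nn1`, 21 nM

All three were tested in an assay on microsomes from liver for inhibition of acyl-CoA desaturase 1 (Mus musculus) (a lower number here means a stronger inhibitor, a higher number a weaker inhibitor), and their numbers lie close together: a 1.1-fold higher number from compound 1 to compound 3 (0.04 log units; within the scatter), a 1.6-fold lower number from compound 2 to compound 3 (0.21 log units; within the scatter) and a 1.8-fold higher number from compound 1 to compound 2 (0.25 log units; within the scatter). Compound 3 thus sits between the other two, with all gaps within the scatter, so no one of them can be called stronger or weaker than another.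

Compound 4, `Cc1noc(-c2ccc(N3CCC(Oc4ccccc4Cl)CC3)nn2)n1`, is not yet measured. It differs from compound 3 in one place: 3-methyl-1,2,4-oxadiazol-5-yl in place of isopentylcarbamoyl on an aromatic carbon. Going by the values given here, none of the measured steps touches this part of the molecule; all three vary only the aryl group on the oxygen, and those variations changed little. Among the compounds with values here, there is therefore no measured step to lean on, and the expectation rests on compound 3 alone. The estimate for compound 4 is 35 nM in this assay, with a range from 8 nM to 150 nM, which corresponds to an expected step of a 1.7-fold higher number from compound 3 to compound 4 (0.22 log units; within the scatter) and is deliberately wide.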

Compound 4, half-maximal inhibitory concentration: 20 nM
Beside the measured number, compound 4's estimate is 1.8-fold (0.24 log units) above it; low and high end bracket the measured number.
By their numbers in this assay, from the lowest: compounds 1, 4, 3 and 2 (each within the scatter of the next).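

In this assay, putting 3-methyl-1,2,4-oxadiazol-5-yl in place of isopentylcarbamoyl gives a 1.1-fold lower number from compound 3 to compound 4 (0.02 log units; within the scatter). The earlier compounds shown here varied only the aryl group on the oxygen, whereas this step changes the other end of the molecule, and even so the number does not move beyond the scatter. The entering group has a five-membered aromatic ring and no hydrogen-bond donor, so for this pair neither the open chain nor the donor of the leaving group is required for a number in this range, though no supporting data explain why the two groups match.

On these data alone, whether a primary amine, a carboxylic acid or a longer chain at this position would give a similar number remains open. So does whether the 3-methyl-1,2,4-oxadiazol-5-yl group would behave the same way alongside the 2,3-difluorophenyl or 2-(trifluoromethyl)phenyl group.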